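Ring Size at the Basic Amine in a Sulfonamide Series

The source may report more compounds than this note shows. Statements on the series, on what has been measured and on what is new or still open speak of the compounds shown alone.

Compound 1, `Cc1cc(C)c(S(=O)(=O)N2CCC(N3CCC(C)CC3)CC2)c(C)c1`: 50000 nM
Compound 2, `CC1CCN(C2CCN(S(=O)(=O)c3ccc(OC(C)C)cc3)CC2)CC1`: 30 nM

Of the compounds shown here, two have been measured in an assay on isolated protein for inhibition of 7-dehydrocholesterol reductase (Homo sapiens); a lower number here means a stronger inhibitor, a higher number a weaker inhibitor. Compound 1 gives 50000 nM, the highest of the two numbers, and so the weaker inhibitor of the pair. Compound 2 gives 30 nM, a far lower number, and the gap between the two lies well beyond the scatter of the assay. Within the data shown here, the two share a sulfonyl-piperidine core but differ at the aryl ring and elsewhere, so no single step between them is defined.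

Compound 3, `Cc1cc(C)c(S(=O)(=O)N2CCC(N3CCCCCC3)CC2)c(C)c1`, has not yet been measured. It differs from compound 1 in one place: azepan-1-yl in place of 4-methylpiperidin-1-yl on a saturated ring carbon. The atoms are the same in number and kind, only joined into a ring of a different size.

Among the measured compounds shown here, no measured pair shows what such a change does in this assay. With the same aryl sulfonyl group as compound 1 kept in place, compound 3 is expected to stay close to compound 1, with a step of a 1.1-fold lower number from compound 1 to compound 3 (0.05 log units; within the scatter) that is not expected to reach beyond the scatter. Compound 3 is therefore estimated at 45000 nM, in a range from 12000 nM to 170000 nM.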

Compound 3, half-maximal inhibitory concentration: 1390 nM
Compound 3: the middle estimate sits 32-fold (1.51 log units) above what was measured; the whole stated range lies above it.
By their numbers in this assay, from the lowest: compound 2; then compound 3; then compound 1.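

In this assay, the position on a saturated ring carbon of the shared core proves sensitive to how the same atoms are joined: azepan-1-yl in place of 4-methylpiperidin-1-yl gives a 36-fold lower number from compound 1 to compound 3 (1.56 log units; beyond the scatter) with the aryl sulfonyl group unchanged. The two groups have the same counts of heavy atoms, donors and acceptors, so these counts alone do not predict the result at this position. Compound 1 and compound 2 differ in more than one place and could not isolate this position, whereas this single change shows that replacing the six-membered ring bearing a methyl group with the seven-membered ring can by itself move the number well beyond the scatter, and no measurement at hand accounts for the size of this step.

The change enlarges the ring and removes the methyl group together, so the compounds shown do not separate the two, and a piperidin-1-yl or a 4-methylazepan-1-yl group at the same place would be needed to tell them apart. On these data alone, it also remains open whether azepan-1-yl would give a step of similar size alongside the aryl sulfonyl group of compound 2.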